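The source may hold more compounds than are shown below. What is called first, only, known or untested is meant among the compounds shown, and "the series" means these compounds.

Measured so far:
compound 1, `N/C(=N\NC(=S)N1CCCCCC1)c1ccccn1`: 18.8%
compound 2, `Cc1cccc(/C(N)=N/NC(=S)N2CCCCC2)n1`: 35%

Both numbers come from a functional assay on A-431 cells (Homo sapiens) for cytotoxicity, read by MTT assay, with a stated time of 72 h, tested at 1 uM; a lower number here means less inhibition of growth, a higher number more inhibition of growth at the concentration tested. Compound 1 has the lower of the two values; compound 2 stands higher, and that gap lies beyond the usual scatter. Compound 2 differs from compound 1 in more than one place, so its higher number cannot be read as the effect of a single change.

Compound 3, `Cc1ccnc(/C(N)=N/NC(=S)N2CCCCCC2)c1`, is not yet measured. It differs from compound 1 by methyl in place of hydrogen on an aromatic carbon, meta to a large group and opposite the ring nitrogen. For the measured compounds named here, no pair of measured compounds shows exactly this one change, so the size of the step is open. Compound 2 also carries a methyl on its ring and gives a higher number, but it differs from compound 1 elsewhere as well, so that comparison is only a hint. A small rise in this assay, possibly no larger than the scatter, is the expectation; the estimated step is a number 6.2 percentage points higher from compound 1 to compound 3 (within the scatter). Compound 3 is expected at 25%, within a range from 10% to 42%.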

Compound 3, percent growth inhibition at one concentration: 36.3%
Beside the measured number, compound 3's estimate is 11.3 percentage points below it; low and high end bracket the measured number.
By their numbers in this assay, from the lowest: compound 1; then compounds 2 and 3 (each within the scatter of the next).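

In this assay, for the compounds shown here, the step is a number 17.5 percentage points higher from compound 1 to compound 3 (beyond the scatter), and this is the first measured pair here that differs in only one place. It shows that methyl in place of hydrogen on an aromatic carbon, meta to a large group and opposite the ring nitrogen, can by itself move the reading beyond the usual scatter, which the earlier comparison of two compounds differing in more than one place could only hint at. No measurement at hand explains why this small change raises the number, so the finding remains an observation about this one pair.

The compounds shown leave open whether a larger or different group at this same position, such as an ethyl, a methoxy, an amine or a chlorine atom, would raise the number further, leave it unchanged or lower it. They also leave open whether the same methyl would give a similar step on a compound other than compound 1, since a single pair cannot establish a general pattern.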